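Moving the Fluorine Around the Benzyloxy Ring

This account rests on a few compounds, and the source may have more. Where it says the series, first, only, none or still open, it means among the compounds named here.

Measured in a functional assay on Huh-7 cells (Homo sapiens) for antiproliferative activity, read by sulforhodamine B assay, with a stated time of 72 h; a lower number here means a stronger inhibitor, a higher number a weaker inhibitor:
compound 1 `FC(F)(F)c1ccc(CN2CCN(Cc3cc(-c4ccc(OCc5ccccc5)cc4)on3)CC2)cc1`: 1700 nM
compound 2 `Cc1ccc(COc2ccc(-c3cc(CN4CCN(Cc5ccc(C(F)(F)F)cc5)CC4)no3)cc2)cc1`: 1500 nM
compound 3 `Fc1ccccc1COc1ccc(-c2cc(CN3CCN(Cc4ccc(C(F)(F)F)cc4)CC3)no2)cc1`: 1500 nM

Compound 3 stands level with compound 2 at the digits shown, the two together giving the lowest numbers of the three, and compound 1 sits only a little apart. Among the compounds with values here, none of the measured steps is large: a 1.1-fold lower number from compound 1 to compound 2 (0.05 log units; within the scatter), a 1.1-fold lower number from compound 1 to compound 3 (0.05 log units; within the scatter) and no change at the digits printed from compound 2 to compound 3 (within the scatter) all lie within the scatter, so the three compounds cannot be told apart in this assay.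

Compound 4 `Fc1cccc(COc2ccc(-c3cc(CN4CCN(Cc5ccc(C(F)(F)F)cc5)CC4)no3)cc2)c1` differs from compound 3 in one place: 3-fluorophenyl in place of 2-fluorophenyl on a saturated chain carbon bound to an oxygen on an aromatic ring. The step that bears most directly on this is the earlier exchange at the same saturated chain carbon, no change at the digits printed from compound 2 to compound 3 (within the scatter), where the number did not move at all. The other two steps, which placed a methyl or a fluorine on an aromatic carbon, were also within the scatter. Because no change at the digits printed from compound 2 to compound 3 (within the scatter) showed no movement, a change at the same place is expected to leave the number where it is. The expected step is therefore no change at the digits printed from compound 3 to compound 4 (within the scatter), none beyond the scatter. The estimate for compound 4 is 1500 nM, with a range from 800 nM to 3000 nM.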

Compound 4, half-maximal inhibitory concentration: 1300 nM
Compound 4: the middle estimate sits 1.2-fold (0.06 log units) above what was measured; the range from low to high includes it.
By their numbers in this assay, from the lowest: compounds 4, 2, 3 and 1 (each within the scatter of the next).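

Moving the fluorine from the 2-fluorophenyl to the 3-fluorophenyl gives a 1.2-fold lower number from compound 3 to compound 4 (0.06 log units; within the scatter) in this assay and is the first comparison here in which only the fluorine's place on this ring changes; at this level of resolution, these two placements cannot be told apart. The wider comparisons read the same way: exchanging the 4-methylphenyl for the 3-fluorophenyl gives a 1.2-fold lower number from compound 2 to compound 4 (0.06 log units; within the scatter) and adding the fluoro to the unsubstituted ring gives a 1.3-fold lower number from compound 1 to compound 4 (0.12 log units; within the scatter) as the result, so none of the four groups shown at this position separates from the others in this assay. The compounds shown offer no measurement that could explain this flat result.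

Still open, on these data alone, is the 4-fluorophenyl, the remaining single-fluorine placement on this ring, and whether a 4-chlorophenyl would behave in the same way. It is also unknown whether a more different group on this ring, such as a carboxylic acid or an amine, would move the number beyond the scatter, which none of these four compounds does.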